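This account rests on a few compounds, and the source may have more. Where it says the series, first, only, none or still open, it means among the compounds named here.

In a functional assay on K562 cells (Homo sapiens), read by MTT assay, with a stated time of 72 h (a lower number here means a stronger inhibitor, a higher number a weaker inhibitor), the three measured compounds stand as follows. Compound 1 `CN(C)c1ncnc2c1c(-c1ccoc1)cn2[C@@H]1O[C@H](CO)[C@@H](O)[C@H]1O` gives 1540 nM. Compound 2 `CSc1ncnc2c1c(-c1ccoc1)cn2[C@@H]1O[C@H](CO)[C@@H](O)[C@H]1O` gives 60 nM. Compound 3 `CSc1ncnc2c1c(-c1cccs1)cn2[C@@H]1O[C@H](CO)[C@@H](O)[C@H]1O` gives 11600 nM.

Compound 2 gives the lowest number of the three. One change from it is dimethylamino in place of methylsulfanyl on an aromatic carbon, and that step was a 26-fold higher number from compound 2 to compound 1 (1.41 log units; beyond the scatter). The other change is in the core, (thiophen-2-yl in place of furan-3-yl on an aromatic carbon), and that step was a 190-fold higher number from compound 2 to compound 3 (2.29 log units; beyond the scatter), so compound 3 gives the highest number of the three.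

Compound 4 `CN(C)c1ncnc2c1c(-c1cccs1)cn2[C@@H]1O[C@H](CO)[C@@H](O)[C@H]1O` has not been measured. It differs from compound 3 by dimethylamino in place of methylsulfanyl on an aromatic carbon, the same change made from compound 2 to compound 1, at the same place, only on the core of compound 3 rather than that of compound 2. The step from compound 3 to compound 4 is expected to be a 10-fold higher number from compound 3 to compound 4 (1.01 log units; beyond the scatter), set beside a 26-fold higher number from compound 2 to compound 1 (1.41 log units; beyond the scatter); this rests on that single earlier step alone, and since compound 3 already gives a high number the assay may report only a limit. Compound 4 is therefore expected to give about 120000 nM, most likely between 30000 nM and 500000 nM.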

Compound 4, half-maximal inhibitory concentration: > 20000 nM
Compound 4: no number, only a limit (the forecaster's own chance of this, stated with the estimate: 45%); the middle value lies beyond the limit too.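

In this assay compound 4 gives > 20000 nM, which is a limit of the assay and not a number. Dimethylamino in place of methylsulfanyl on the thiophen-2-yl compounds gives an at least 1.7-fold higher number from compound 3 to compound 4 (0.23 log units; that floor lies within the scatter), a floor too small to show that the change carries over to this core with any firm effect, and setting it beside the earlier step gives no verdict on its size: the same change on two cores in this assay, a 26-fold higher number (1.41 log units; beyond the scatter) from compound 2 to compound 1 and an at least 1.7-fold higher number (0.23 log units; that floor lies within the scatter) from compound 3 to compound 4; the limit leaves it open whether they differ. Thiophen-2-yl in place of furan-3-yl gives an at least 12-fold higher number from compound 1 to compound 4 (1.11 log units; beyond the scatter), so this change raises the number beyond the scatter in both settings, although its exact size in the second setting stays unfixed: the same change on two cores in this assay, a 190-fold higher number (2.29 log units; beyond the scatter) from compound 2 to compound 3 and an at least 12-fold higher number (1.11 log units; beyond the scatter) from compound 1 to compound 4; the limit leaves it open whether they differ.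

From the compounds shown here alone, the true size of the dimethylamino step on the core of compound 3 remains open, as a limit can only give its floor. Also open, going by these compounds, is how an amine, a methoxy group or a longer chain such as ethylsulfanyl would read in place of methylsulfanyl, and whether the large gap between the furan-3-yl and thiophen-2-yl compounds would hold for a simple alkyl chain at that place.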